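A few compounds are considered here, and "the series" means these few. Any claim that something is new, unique, unknown or untested is made for them only; others in the source may bear on it.

In a physicochemical assay for lipophilicity, at pH 7.4 (on this read-out lower numbers stand for lower lipophilicity and higher numbers for higher lipophilicity), compound 1 `COc1ccc(C2CCc3nc[nH]c3C2)cc1` gives 2.6 and compound 2 `COc1cccc(C2CCc3nc[nH]c3C2)c1` gives 2.6, so compound 2 stands level with compound 1. Compound 3 `c1ccc(C2CCc3nc[nH]c3C2)cc1` follows from compound 2 by hydrogen in place of methoxy on an aromatic carbon. Going by the values given here, no measured pair shows this change, so the expectation rests on the structural change alone. A small step toward lower numbers, probably none beyond the scatter, is expected: a number 0.10 log units lower from compound 2 to compound 3 (within the scatter). For compound 3 the estimated value in this assay is 2.5, with an expected range of 2.2 to 2.8.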

Compound 3, distribution coefficient: 2.6
Estimate against measurement, compound 3: 0.10 log units below, within the range that was stated.
By their numbers in this assay, from the lowest: compounds 1, 2 and 3 (each within the scatter of the next).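

Hydrogen in place of methoxy on an aromatic carbon leaves the read-out of this assay without a detectable shift, both for the first methoxy placement (no change at the digits printed from compound 2 to compound 3 (within the scatter)) and for the second (no change at the digits printed from compound 1 to compound 3 (within the scatter)). In this small set, therefore, the methoxy compounds cannot be told apart from the compound carrying hydrogen, whichever of the two methoxy placements is compared. No available data speak to the reason for this outcome.

From the compounds shown here alone, whether an amine or a carboxylic acid at this place would separate from hydrogen remains open. So does the effect of a longer chain in place of methoxy.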